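The compounds below may be only part of what the source reports. "The series", "measured", "known", "first", "only" and "open" are said of these compounds alone.

Measured so far:
compound 1 `COc1cc(Cl)cc(-c2nn(-c3cccc(NC(=O)Nc4cccc(C(F)(F)F)c4)c3)cc2-c2ccncc2)c1` — 15.5%
compound 2 `O=C(Nc1cccc(-n2cc(-c3ccncc3)c(-c3cc(O)cc(Cl)c3)n2)c1)Nc1ccc(Cl)c(Cl)c1` — -44.2%

In a functional assay on HOP-62 cells (Homo sapiens) for inhibition, read by sulforhodamine B assay, with a stated time of 48 h, tested at 10 uM (a higher number here means a weaker effect of the compound at the concentration tested, a lower number a stronger effect), compound 2 gives -44.2%, the lowest of the two numbers; compound 1, the nearest, gives 15.5%, a gap beyond the scatter. Compound 3 `COc1cc(Cl)cc(-c2nn(-c3cccc(NC(=O)Nc4ccc(Cl)c(Cl)c4)c3)cc2-c2ccncc2)c1` is not yet measured. It differs from compound 2 by methyl in place of hydrogen on an oxygen on an aromatic ring. Among the compounds with values here, no measured pair isolates this change, so its size in this assay is unknown; a step within the scatter, or a modest move toward weaker effect, is expected. For compound 3 the estimate is -30%, range -65% to 5%, an expected step of a number 14.2 percentage points higher from compound 2 to compound 3 (beyond the scatter).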

Compound 3, a percentage reported as activity, at one concentration (the size of the read-out at that concentration, not a potency): 15.7%
Compound 3: middle estimate off by 45.7 percentage points, on the low side; measured number outside the range, above it.
By their numbers in this assay, from the lowest: compound 2; then compounds 1 and 3 (each within the scatter of the next).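

In this assay, changing hydroxy to methoxy on the aromatic ring gives a large step, a number 59.9 percentage points higher from compound 2 to compound 3 (beyond the scatter), so the read-out at this position depends strongly on the hydrogen on that oxygen. With methoxy in place, 3,4-dichlorophenyl in place of 3-(trifluoromethyl)phenyl on the amide-type nitrogen gives a number 0.2 percentage points higher from compound 1 to compound 3 (within the scatter), so that exchange does not separate this pair. Nothing at hand accounts for the hydroxy to methoxy step. Going by these compounds, whether an amine or an ethoxy group at this position would track the hydroxy or the methoxy remains open, as does whether the exchange on the amide-type nitrogen stays as small with hydroxy present.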